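Hydroxy on the Ethyl Chain: Cytotoxicity Expected Unchanged

The compounds below may be only part of what the source reports. "The series", "measured", "known", "first", "only" and "open" are said of these compounds alone.

Compound 1 `CCn1ncc2c(Nc3ccc(OC(F)(F)F)cc3)ncnc21` was tested in an ADME assay on BaF3 cells (Mus musculus) for cytotoxicity; a lower number here means that less compound is needed, a higher number that more compound is needed for the effect. In this assay compound 1 gives > 10000 nM, which is a limit of the assay and not a number. Two further compounds share this outcome. In this assay compound 2 `NC(=O)CCn1ccc2c(Nc3ccc(OC(F)(F)F)cc3)ncnc21` gives > 10000 nM, again a limit. In this assay compound 3 `CS(=O)(=O)c1cccc(-c2cc(Nc3ccc(OC(F)(F)F)cc3)ncn2)c1` gives > 10000 nM, also a limit. Within the data shown here, all three thus rest at the limit of > 10000 nM in this assay, at which 3 of the 3 values shown sit, and no measured step between them can be drawn.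

Compound 4 `OCCn1ncc2c(Nc3ccc(OC(F)(F)F)cc3)ncnc21` has not yet been measured in this assay. It differs from compound 1 by hydroxy in place of hydrogen on a saturated chain carbon, two bonds along the chain from an aromatic nitrogen. Since every value shown sits at the limit, no direction of change can be read from the data, and nothing in them points to a gain in cytotoxicity. The expected step is a number no higher from compound 1 to compound 4 (the limit leaves the size open), none beyond the scatter. Compound 4 is therefore expected to give about 10000 nM in this assay, within a range from 5000 nM to 30000 nM, and most likely to be reported once more as a limit.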

Compound 4, half-maximal effective concentration: > 10000 nM
Compound 4: no number, only a limit; the forecaster's own chance of this, stated with the estimate: 85%; the middle value sits exactly at the limit.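

In this assay, among these compounds, no step from compound 1 to compound 4 can be read, because both values are limits and not numbers: the limit of > 10000 nM in this assay, at which 4 of the 4 values shown sit.

The compounds shown leave open what number any of them would reach, and whether hydroxy in place of hydrogen changes the read-out at all.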